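Swapping Methoxy for Fluoro: Expected Cytotoxicity of Compound 4

A few compounds are considered here, and "the series" means these few. Any claim that something is new, unique, unknown or untested is made for them only; others in the source may bear on it.

Of the compounds shown here, three from this series have been measured in an ADME assay on THP-1 cells (Homo sapiens) for cytotoxicity, read by flow cytometry and propidium iodide staining, with a stated time of 72 h; on this read-out higher numbers stand for weaker inhibition and lower numbers for stronger inhibition. Compound 1 `COc1ccccc1/C=C/C(=O)c1cc(NC(C)=O)ccc1O` gives only a limit of the assay, > 125000 nM. Compound 2 `CC(=O)Nc1ccc2oc(-c3ccccc3)cc(=O)c2c1` gives 97000 nM, and compound 3 `COc1ccccc1-c1cc(=O)c2cc(NC(C)=O)ccc2o1` gives 50000 nM; compound 3 thus holds the lowest of the two numbers, with compound 2 nearest to it. For the measured compounds named here, the one single-point step among the measured compounds is a 1.9-fold lower number from compound 2 to compound 3 (0.29 log units; within the scatter). The unmeasured compound 4 `CC(=O)Nc1ccc2oc(-c3ccccc3F)cc(=O)c2c1` differs from compound 3 in one place: fluoro in place of methoxy on an aromatic carbon. Going by the values given here, the only measured step that bears on this change is the one in which the methoxy entered, and its effect stayed within the scatter of the measurement. Replacing that methoxy with fluoro therefore gives no reason to expect a step beyond the scatter in this assay in either direction. Compound 4 is accordingly expected to give 70000 nM, with a range from 30000 nM to 140000 nM. The estimated step is a 1.4-fold higher number from compound 3 to compound 4 (0.15 log units; within the scatter).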

Compound 4, half-maximal inhibitory concentration: > 125000 nM
Compound 4 was reported as a limit; the forecaster's own chance of this, stated with the estimate: 20%; middle value at least 1.7-fold (0.25 log units) from the limit.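

In this assay, fluoro in place of methoxy on an aromatic carbon, ortho to a large group, gives an at least 2.5-fold higher number from compound 3 to compound 4 (0.39 log units; beyond the scatter). For the compounds shown here, this is the first one-place step that lies beyond the scatter, showing that this position responds to the group placed there, which the earlier step from hydrogen to methoxy could not show. Fluoro in place of hydrogen gives an at least 1.2-fold higher number from compound 2 to compound 4 (0.11 log units; that floor lies within the scatter), and compound 4 is a limit rather than a number, so neither step has a known full size: the limit of > 125000 nM in this assay, at which 2 of the 4 values shown sit.

The compounds shown leave open how an amine, a hydroxyl or a longer chain such as ethoxy would read at this position. They also do not say whether the same change would read alike on the core of compound 1, which also carries methoxy.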